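Thiophene in place of halophenyl at the benzylic carbon

A few compounds are considered here, and "the series" means these few. Any claim that something is new, unique, unknown or untested is made for them only; others in the source may bear on it.

Working notes on the shared core of compound 1 `Cc1nc(N)sc1CCCN/C(N)=N/C(=O)N[C@H](C)c1ccccc1`, measured in a functional assay on Right cardiac atrium for agonist activity at histamine H2 receptor (Cavia porcellus), with a stated time of 30 min, in the presence of a further agent that is not named here; on this read-out higher numbers stand for an effect only at larger amounts of compound and lower numbers for an effect already at smaller amounts. Compound 1 gives 7.59 nM. Compound 2 `Cc1nc(N)sc1CCCN/C(N)=N/C(=O)NC(C)c1ccc(Br)cc1` gives 55 nM, and compound 3 `Cc1nc(N)sc1CCCN/C(N)=N/C(=O)NC(C)c1ccc(Cl)cc1` gives 24.6 nM. Among these three numbers compound 3 stands second highest: its nearest neighbour is compound 2, its furthest compound 1. Among the measured compounds shown here, the one single-point step in the set, a 2.2-fold lower number from compound 2 to compound 3 (0.35 log units; beyond the scatter), shows that exchanging one halogen on the aromatic ring moves the number modestly and beyond the scatter.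

Compound 4 `Cc1nc(N)sc1CCCN/C(N)=N/C(=O)NC(C)c1cccs1` has not been measured. It differs from compound 3 by thiophen-2-yl in place of 4-chlorophenyl on a saturated chain carbon bound to an amide-type nitrogen and a saturated chain carbon. For the measured compounds named here, no measured step exchanges the whole aromatic ring, so the halogen step is only an indirect guide; it shows that the read-out responds to what sits on this ring. Compound 1, which carries the unsubstituted phenyl, gives the lowest number of the three. For compound 4 a lower number than compound 3 is therefore expected, a step of a 2.1-fold lower number from compound 3 to compound 4 (0.31 log units; beyond the scatter), though with wide uncertainty. The estimate for compound 4 in this assay is 12 nM, with a range from 4 nM to 40 nM.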

Compound 4, half-maximal effective concentration: 10 nM
Compound 4: middle estimate off by 1.2-fold (0.08 log units), on the high side; the measured number falls inside the stated range.
By their numbers in this assay, from the lowest: compounds 1 and 4 (each within the scatter of the next); then compound 3; then compound 2.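

In this assay, the whole aromatic ring on the saturated chain carbon bound to an amide-type nitrogen and a saturated chain carbon can now be compared directly, not only through a halogen exchange: thiophen-2-yl in place of 4-chlorophenyl gives (a 2.5-fold lower number from compound 3 to compound 4 (0.39 log units; beyond the scatter)), and thiophen-2-yl in place of 4-bromophenyl gives (a 5.5-fold lower number from compound 2 to compound 4 (0.74 log units; beyond the scatter)). With 1-(thiophen-2-yl)ethyl in place of 1-phenylethyl, the step is (a 1.3-fold higher number from compound 1 to compound 4 (0.12 log units; within the scatter)), so on this read-out the five-membered aromatic ring with 1 hetero atom cannot be told apart from the unsubstituted phenyl ring. No measurement at hand accounts for any of these steps.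

From the compounds shown here alone, whether this tolerance extends to thiophen-3-yl, furan-2-yl or pyridin-2-yl at the same carbon remains open, as does the effect of a chloro or bromo group on the thiophene ring itself. Also unsettled is how much the comparison with compound 1 depends on configuration, since compound 1 is drawn with a defined configuration at this carbon and compound 4 without one.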